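Side-chain extension on the shared core

The source may hold more compounds than are shown below. What is called first, only, known or untested is meant among the compounds shown, and "the series" means these compounds.

Measured so far:
compound 1, `O=C(O)c1cn(Cc2ccc(-n3cccn3)cc2)c2cc(N3C[C@H]4CCNC[C@H]4C3)c(F)cc2c1=O`, 31300 nM
compound 2, `CN[C@@H]1CCN(c2cc3c(cc2F)c(=O)c(C(=O)O)cn3Cc2ccc(-c3ccccc3)cc2)C1`, 34800 nM

Both numbers come from an assay on isolated protein for inhibition of DNA topoisomerase 1 (Homo sapiens), with a stated time of 15 min; on this read-out lower numbers stand for stronger inhibition and higher numbers for weaker inhibition. For the measured compounds named here, compound 2 holds the highest of the two numbers, but the nearest, compound 1, sits within the usual scatter of it, so the two values show only that the compounds behave alike. Going by the values given here, no step between measured compounds that differ in one place is available.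

Compound 3, `CNC[C@@H]1CCN(c2cc3c(cc2F)c(=O)c(C(=O)O)cn3Cc2ccc(-c3ccccc3)cc2)C1`, has not been measured. It differs from compound 2 as (methylamino)methyl in place of methylamino on a saturated ring carbon. With no comparable change among the measured compounds, the size of the step can only be judged from the closeness of compound 1 and compound 2. The step from compound 2 to compound 3 is expected to be small and in no set direction, not beyond the scatter, as a 1.0-fold higher number from compound 2 to compound 3 (0.00 log units; within the scatter). For compound 3 the estimated value is 35000 nM, with a range from 12000 nM to 100000 nM.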

Compound 3, half-maximal inhibitory concentration: 168000 nM
Compound 3: middle estimate off by 4.8-fold (0.68 log units), on the low side, outside the stated range (above it).
By their numbers in this assay, from the lowest: compounds 1 and 2 (each within the scatter of the next); then compound 3.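

In this assay, this saturated ring carbon is not indifferent to how the amine is attached: going from 3-(methylamino)pyrrolidin-1-yl to 3-((methylamino)methyl)pyrrolidin-1-yl gives a 4.8-fold higher number from compound 2 to compound 3 (0.68 log units; beyond the scatter). Compound 1 and compound 2 differ in more than one place, so they offered no reading of a single change; this pair gives the first, and it points towards weaker inhibition. The methylamino group of compound 2 is therefore the better of the two side chains compared here, although nothing at hand accounts for the difference.

From the compounds shown here alone, whether a longer chain, such as 2-(methylamino)ethyl, would raise the number further remains open. So does the outcome with a primary amine, such as aminomethyl, or a dimethylamino group on the same ring carbon.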